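Double bond geometry change in the furan-bearing lactone series

A few compounds are considered here, and "the series" means these few. Any claim that something is new, unique, unknown or untested is made for them only; others in the source may bear on it.

Three compounds share a hydroxylated lactone core carrying a long unsaturated side chain that ends in furan rings. Compound 1 `CC1=C(O)[C@@H](C/C(C)=C\CCC(C)/C=C/C/C(C)=C/CCc2ccoc2)OC1=O` gives 16.9 ug/mL in a functional assay on A549 cells (Homo sapiens) for cytotoxicity; on this read-out lower numbers stand for an effect already at smaller amounts and higher numbers for an effect only at larger amounts of compound. Compound 2 `CC1=C(O)/C(=C/[C@H](C)CC/C=C(/C)CCCc2coc(Cc3ccoc3)c2)OC1=O` gives 3.8 ug/mL in this assay, and compound 3 `CC1=C(O)/C(=C\[C@H](C)CCC/C(C)=C/CCc2coc(Cc3ccoc3)c2)OC1=O` gives 4.98 ug/mL. Compound 2 thus carries the lowest number of the three: the gap to compound 3 lies within the scatter, so the two cannot be ordered, while the gap to compound 1 lies beyond it.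

Compound 4 `CC1=C(O)/C(=C\[C@H](C)CC/C=C(/C)CCCc2coc(Cc3ccoc3)c2)OC1=O` is not yet measured in this assay. Compared with compound 2 it shows (the two compounds have the same atoms and bonds and differ only in configuration as drawn: 1 of 3 stereo elements differ; a double bond is drawn Z in compound 2 and E in compound 4). Nothing else in the structure moves. Within the data shown here, no measured pair differs only in this way, so there is no directly comparable step to lean on; compound 3, which carries the other geometry in a differently placed double bond, sits within the scatter of compound 2, which suggests the read-out is not very sensitive to such changes.

For compound 4 a step of a 1.2-fold higher number from compound 2 to compound 4 (0.07 log units; within the scatter) from compound 2 is expected, essentially none beyond the scatter. Compound 4 is therefore estimated at 4.5 ug/mL, with a range from 2 ug/mL to 10 ug/mL.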

Compound 4, concentration for half-maximal effect: 3.8 ug/mL
For compound 4 the middle estimate is 1.2-fold (0.07 log units) above the measured one; measured number inside the range.
By their numbers in this assay, from the lowest: compounds 2, 4 and 3 (each within the scatter of the next); then compound 1.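

The series now holds a pair that differs in one place only, and in this assay the read-out shows no change at the digits printed from compound 2 to compound 4 (within the scatter). Until this pair, no single step could be read in the series, so any reading of double-bond geometry rested on compounds that differ in more than one place; here the comparison isolates the drawn geometry of one double bond, and the result can be tied to that element alone: the fact that compounds 2 and 4 differ only in the configuration as drawn For this double bond, then, Z and E as drawn cannot be told apart in this assay, a statement that rests on this one pair and does not extend to the rest of the structure.

The compounds shown leave open whether the same holds for the remaining double bond of this side chain or for the configuration of the stereocentre, since neither is changed on its own in any pair here. They also leave open how the read-out in this assay would respond if the terminal furan gave way to an amine or a carboxylic acid, or if the side chain were replaced by a longer chain.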